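The source may hold more compounds than are shown below. What is called first, only, known or untested is meant among the compounds shown, and "the series" means these compounds.

Working notes on the series, read in a functional assay on SW-620 cells (Homo sapiens) for cytotoxicity, read by MTT assay, with a stated time of 72 h; on this read-out lower numbers stand for stronger inhibition and higher numbers for weaker inhibition. Compound 1 (`O=C1CS/C(=N\c2csc(-c3ccc(Cl)cc3)c2)N1`) reads > 50000 nM, which is a limit of the assay and not a number. Within the data shown here, compound 2 (`COc1cccc(N2C(=O)CS/C2=N\c2csc(-c3ccc(Cl)cc3)c2)c1`) gives 33000 nM, the only true number so far. The other reading marks (the limit of > 50000 nM in this assay, at which 1 of the 2 values shown sits).

Compound 3 (`O=C1CS/C(=N\c2csc(-c3ccc(Cl)cc3)c2)N1c1ccc(Cl)cc1`) differs from compound 2 as follows: 4-chlorophenyl in place of 3-methoxyphenyl on an amide-type nitrogen in a ring. In words, 4-chlorophenyl stands in place of 3-methoxyphenyl on an amide-type nitrogen in a ring.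

Among the measured compounds shown here, only one measured step bears on this position: an at least 1.5-fold lower number from compound 1 to compound 2 (0.18 log units; that floor lies within the scatter). It replaces hydrogen with an aryl group rather than exchanging one aryl group for another, so it is only a loose guide. No change beyond the scatter is therefore expected in this assay, in either direction. The expected step is a 1.1-fold lower number from compound 2 to compound 3 (0.04 log units; within the scatter). For compound 3 the estimated value is 30000 nM, with an expected range of 12000 nM to 60000 nM.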

Compound 3, half-maximal inhibitory concentration: > 50000 nM
Compound 3 gave a limit, no number; the forecaster's own chance of this, stated with the estimate: 35%; middle value at least 1.6-fold (0.22 log units) away from the limit.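

In this assay compound 3 gives > 50000 nM, a limit of the assay and not a number. From the compounds shown here alone, exchanging 3-methoxyphenyl for 4-chlorophenyl on the amide-type nitrogen gives an at least 1.5-fold higher number from compound 2 to compound 3 (0.18 log units; that floor lies within the scatter), so the exchange does not lower the number, though its true size stays unknown and only its floor lies within the scatter. The step from compound 1 to compound 3 cannot be read, and most of the series now sits at the ceiling of the assay: the limit of > 50000 nM in this assay, at which 2 of the 3 values shown sit.

The exchange alters both the substituent on the phenyl ring and its place, so the two effects remain unseparated. Going by these compounds, what an aminoethyl chain or a carboxylic acid on this nitrogen would read also stays open.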